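Ester to acid on a series at the assay limit

The source may report more compounds than this note shows. Statements on the series, on what has been measured and on what is new or still open speak of the compounds shown alone.

Measured in a functional assay on KB cells (Homo sapiens) for antiproliferative activity, read by MTT assay, with a stated time of 72 h; on this read-out lower numbers stand for stronger inhibition and higher numbers for weaker inhibition:
- Compound 1 `CCOC(=O)c1cc(-c2cc(OC)c(OC)c(OC)c2)c(-c2ccc(OC)c([N+](=O)[O-])c2)s1`: 15800 nM
- Compound 2 `CCOC(=O)c1cc(-c2ccc(OC)c(OCc3ccccc3)c2)c(-c2cc(OC)c(OC)c(OC)c2)s1`: > 100000 nM, a limit
- Compound 3 `CCOC(=O)c1cc(-c2ccc(OC)c(O)c2)c(-c2cc(OC)c(OC)c(OC)c2)s1`: > 100000 nM, a limit

Compound 3 gives no number in this assay. Its > 100000 nM is a limit of the assay, and it stands at the limit of > 100000 nM in this assay, at which 2 of the 3 values shown sit.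

Compound 4 `COc1ccc(-c2cc(C(=O)O)sc2-c2cc(OC)c(OC)c(OC)c2)cc1O` is not yet measured. It differs from compound 3 by hydrogen in place of ethyl on an oxygen next to a carbonyl group, or ethoxycarbonyl to carboxy.

Among the compounds with values here, the only measured step is a step that the two limits leave unreadable from compound 2 to compound 3. It concerns a different place and has no readable size, so it offers no guide to the size of this change. Within the data shown here, compound 1 is the only compound with a number, at 15800 nM, and it keeps the ethoxycarbonyl group. With no readable step to build on, no change beyond the scatter is expected in this assay, and a further limit is the likeliest report.

The expected step is a number no higher from compound 3 to compound 4 (the limit leaves the size open).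

Compound 4 is estimated at 100000 nM, with an expected range of 30000 nM to 300000 nM.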

Compound 4, half-maximal inhibitory concentration: 21800 nM
The estimate for compound 4 lay 4.6-fold (0.66 log units) above the measured number; measured number outside the range, below it.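

In this assay, the change from ethoxycarbonyl to carboxy gives an at least 4.5-fold lower number from compound 3 to compound 4 (0.66 log units; beyond the scatter). This position therefore responds to substitution, and a measurable number does not depend on keeping the ethoxycarbonyl group, since compound 4 carries a carboxy group there and gives 21800 nM. Compound 3 has only a limit, > 100000 nM, so the step sets a minimum size rather than an exact one: the limit of > 100000 nM in this assay, at which 2 of the 4 values shown sit.

As far as these compounds go, the step from compound 2 to compound 3 cannot be read, so it remains open whether the carboxy group would give a similar change with a benzyl group on the ring oxygen. Also open, from the compounds shown here alone, is whether a primary amide or a methyl ester in place of the carboxy group would give a number in this assay.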